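This account rests on a few compounds, and the source may have more. Where it says the series, first, only, none or still open, it means among the compounds named here.

Three measured members and one open one. In a functional assay on NCI-H460 cells (Homo sapiens) for cytotoxicity, read by resazurin assay, with a stated time of 72 h (a lower number here means a stronger inhibitor, a higher number a weaker inhibitor), compound 1 `COc1cc(/C=C/C(=O)OC(C)CCOc2no[n+]([O-])c2S(=O)(=O)c2ccccc2)ccc1O` gives 420 nM. Compound 2 `COc1cc(/C=C/C(=O)OCCCO[N+](=O)[O-])ccc1O` gives 29000 nM. Compound 3 `COc1cc(/C=C/C(=O)OCCCO[N+](=O)[O-])ccc1OCCCO[N+](=O)[O-]` reaches only the assay limit of > 50000 nM and so stands among the numbers shown as a limit rather than a value. Among the measured compounds shown here, the one measured step, an at least 1.7-fold higher number from compound 2 to compound 3 (0.23 log units; that floor lies within the scatter), puts in a 3-(nitrooxy)propyl chain and ends at the limit (the limit of > 50000 nM in this assay, at which 1 of the 3 values shown sits), so its true size remains open. For the measured compounds named here, compound 4 `O=C(/C=C/c1ccc(OCCCO[N+](=O)[O-])c(O)c1)OCCCO[N+](=O)[O-]` differs by hydrogen in place of methyl on an oxygen on an aromatic ring, a change no measured pair shows. With nothing to draw on, no shift beyond the scatter in either direction is expected; the step expected is a step that the limit leaves unreadable from compound 3 to compound 4. Compound 4 is therefore estimated at 60000 nM, within 20000 nM to 200000 nM, most likely again reported only as a limit.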

Compound 4, half-maximal inhibitory concentration: 9580 nM
Beside the measured number, compound 4's estimate is 6.3-fold (0.80 log units) above it; measured number outside the range, below it.
By their numbers in this assay, from the lowest: compound 1; then compound 4; then compound 2. At a limit, above all of these: compound 3.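

Hydrogen in place of methyl on an oxygen on an aromatic ring gives an at least 5.2-fold lower number from compound 3 to compound 4 (0.71 log units; beyond the scatter) in this assay, so this position responds to the loss of a single carbon, which the earlier compounds did not show. The true size stays a floor because compound 3 stands at a limit: the limit of > 50000 nM in this assay, at which 1 of the 4 values shown sits.

Among the compounds shown here, whether the same change acts alike on another member of the series remains open, as only this one pair carries it. Also open, from the compounds shown here alone, is how an ethoxy group or a longer chain ending in a carboxylic acid would read on that oxygen.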